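A few compounds are considered here, and "the series" means these few. Any claim that something is new, unique, unknown or untested is made for them only; others in the source may bear on it.

Three measured compounds share one core. In a functional assay on MGC-803 cells (Homo sapiens) for inhibition, read by MTT assay, with a stated time of 72 h (a lower number here means a stronger inhibitor, a higher number a weaker inhibitor), compound 1 `O=C(CSc1nc(Nc2ccccc2)c2ccccc2n1)Nc1cccc(F)c1` gives 12700 nM, compound 2 `C=CC(=O)Nc1cccc(NC(=O)CSc2nc(Nc3ccccc3)c3ccccc3n2)c1` gives 7310 nM and compound 3 `O=C(CSc1nc(Nc2ccccc2)c2ccccc2n1)Nc1ccc(Cl)cc1Cl` gives 12300 nM. On these numbers compound 3 stands second highest of the three, nearest to compound 1 and furthest from compound 2, yet all three lie within the scatter of one another: a 1.7-fold lower number from compound 1 to compound 2 (0.24 log units; within the scatter), a 1.0-fold lower number from compound 1 to compound 3 (0.01 log units; within the scatter) and a 1.7-fold higher number from compound 2 to compound 3 (0.23 log units; within the scatter). Compound 4 `O=C(CSc1nc(Nc2ccccc2)c2ccccc2n1)Nc1ccc(Cl)c(Cl)c1` differs from compound 3 in one place: 3,4-dichlorophenyl in place of 2,4-dichlorophenyl on an amide-type nitrogen. Within the data shown here, no measured step moves a chlorine around this ring; the step bearing most closely on it is the exchange of the whole ring, a 1.0-fold lower number from compound 1 to compound 3 (0.01 log units; within the scatter), which stayed within the scatter, as did the change of a substituent on that ring, a 1.7-fold lower number from compound 1 to compound 2 (0.24 log units; within the scatter). Since every step among the measured compounds was within the scatter, no step beyond the scatter is expected in this assay for compound 4 either. Compound 4 is therefore expected to give about 12000 nM, between 5000 nM and 30000 nM. The expected step is a 1.0-fold lower number from compound 3 to compound 4 (0.01 log units; within the scatter).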

Compound 4, half-maximal inhibitory concentration: 37900 nM
Beside the measured number, compound 4's estimate is 3.2-fold (0.50 log units) below it; the measured number lies above the stated range.
By their numbers in this assay, from the lowest: compounds 2, 3 and 1 (each within the scatter of the next); then compound 4.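

In this assay the ring on the amide-type nitrogen can move the number beyond the scatter, which no earlier step had shown: 3,4-dichlorophenyl in place of 2,4-dichlorophenyl, with the same atoms and the same counts, gives a 3.1-fold higher number from compound 3 to compound 4 (0.49 log units; beyond the scatter), so the arrangement of the two chlorines matters here even though the exchange of the whole ring from compound 1 to compound 3 did not shift the number. Compound 4 also stands apart from the other two, with a 5.2-fold higher number from compound 2 to compound 4 (0.71 log units; beyond the scatter) and a 3.0-fold higher number from compound 1 to compound 4 (0.47 log units; beyond the scatter), which makes it the weakest of the four, though all these steps are modest. Nothing available explains why this change raises the number.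

The compounds shown leave open whether a 3-chlorophenyl or a 4-chlorophenyl group alone would give a number like that of compound 4. They also leave open how a methoxy group, an amine or a carboxylic acid on this ring would read in this assay.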